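The compounds below may be only part of what the source reports. "The series", "measured", "known", "first", "only" and "open" are said of these compounds alone.

Working notes on the series. The shared core of compound 1 `O=C(N/N=C/c1cccc(Cl)c1Cl)Nc1ccc(Oc2ccnc3[nH]ccc23)c(F)c1` gives "not active" (no number reported) in a functional assay on PC-3 cells (Homo sapiens) for antiproliferative activity, read by MTT assay, with a stated time of 72 h; a lower number here means a stronger inhibitor, a higher number a weaker inhibitor. Compound 2 `O=C(N/N=C/c1ccc(O)cc1)Nc1ccc(Oc2ccnc3[nH]ccc23)c(F)c1` gives 2780 nM. Compound 3 `O=C(N/N=C/c1ccccc1)Nc1ccc(Oc2ccnc3[nH]ccc23)cc1` gives 10200 nM, the highest of the two numbers on hand; the value of compound 2 is lower, and that gap lies beyond the scatter. Compound 4 `CN(C)CCn1cccc1/C=N/NC(=O)Nc1ccc(Oc2ccnc3[nH]ccc23)cc1` has not been measured; it differs from compound 3 in one place: 1-(2-(dimethylamino)ethyl)-1H-pyrrol-2-yl in place of phenyl on a carbon with a double bond to nitrogen. Among the measured compounds shown here, no step of this kind has been measured here, so the direction of the step is uncertain; a small step is expected, possibly toward a lower number, with a fair chance that it stays within the scatter. The value of compound 4 is estimated at 6000 nM, with a range from 2000 nM to 20000 nM, meaning an expected step of a 1.7-fold lower number from compound 3 to compound 4 (0.23 log units; within the scatter).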

Compound 4, half-maximal inhibitory concentration: 3930 nM
Compound 4: middle estimate off by 1.5-fold (0.18 log units), on the high side, and the stated range covers the measured number.
By their numbers in this assay, from the lowest: compounds 2 and 4 (each within the scatter of the next); then compound 3.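

Among the compounds shown here, on a carbon with a double bond to nitrogen, 1-(2-(dimethylamino)ethyl)-1H-pyrrol-2-yl in place of phenyl gives a 2.6-fold lower number from compound 3 to compound 4 (0.41 log units; beyond the scatter) in this assay, the only single-place step, and it lies beyond the scatter. This place therefore accepts a larger group, with a five-membered aromatic ring and a dimethylamino chain, without any loss of activity. Nothing measured here accounts for the step. The compounds shown do not separate the contribution of the ring from that of the chain. An unsubstituted pyrrol-2-yl, or a morpholine at the end of the chain, would divide the two.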